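Dithiocarbamate amine swaps on a benzamide series

The source may report more compounds than this note shows. Statements on the series, on what has been measured and on what is new or still open speak of the compounds shown alone.

Measured so far, in a functional assay on HeLa cells (Homo sapiens) for antiproliferative activity, read by CCK-8 assay, with a stated time of 72 h, tested at 2 uM; on this read-out higher numbers stand for a stronger effect at the one concentration tested and lower numbers for a weaker effect:
compound 1 `CN(Cc1cccnc1)C(=S)SCc1ccc(C(=O)Nc2ccccc2N)cc1` — 16.4%
compound 2 `Nc1ccccc1NC(=O)c1ccc(CSC(=S)N2CCN(c3ccccc3F)CC2)cc1` — 17.5%
compound 3 `Nc1ccccc1NC(=O)c1ccc(CSC(=S)N2CCc3cc(Cl)ccc32)cc1` — 40.1%

Compound 3 stands highest of the three numbers in this assay. Compound 2 is the nearest, a number beyond the scatter below it, and compound 1 is the furthest, also beyond the scatter.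

The next compound, compound 4 `CN1CCN(C(=S)SCc2ccc(C(=O)Nc3ccccc3N)cc2)CC1`, differs from compound 3 only at the amine on the thiocarbonyl carbon: 4-methylpiperazin-1-yl in place of 5-chloro-2,3-dihydro-1H-indol-1-yl on a thiocarbonyl carbon.

Among the measured compounds shown here, one measured step bears directly on this position: a number 23.7 percentage points higher from compound 1 to compound 3 (beyond the scatter), a modest rise when the 5-chloro-2,3-dihydro-1H-indol-1-yl group entered in place of the open-chain amine. Compound 2, which carries a piperazine amine on the same thiocarbonyl carbon, gives 17.5%, within the scatter of compound 1. Both non-indoline amines thus sit at the low end, while the single indoline sits at the high end.

Compound 4 brings back a piperazine-type amine. A drop of roughly the same size is therefore expected, a number 22.1 percentage points lower from compound 3 to compound 4 (beyond the scatter), placing compound 4 near compounds 1 and 2. The estimate for compound 4 in this assay is 18%, with a range from 8% to 32%.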

Compound 4, a percentage reported as inhibition, at one concentration (the size of the read-out at that concentration, not a potency): 52.6%
Beside the measured number, compound 4's estimate is 34.6 percentage points below it; measured number above the stated range.
By their numbers in this assay, from the lowest: compounds 1 and 2 (each within the scatter of the next); then compound 3; then compound 4.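

In this assay, 4-methylpiperazin-1-yl in place of 5-chloro-2,3-dihydro-1H-indol-1-yl on a thiocarbonyl carbon gives a number 12.5 percentage points higher from compound 3 to compound 4 (beyond the scatter) and puts compound 4 highest of the four, so the 5-chloro-2,3-dihydro-1H-indol-1-yl group is not needed for the highest number in this set. A piperazine amine as such does not fix the level either: methyl in place of 2-fluorophenyl on an amine nitrogen in a ring gives a number 35.1 percentage points higher from compound 2 to compound 4 (beyond the scatter) in this assay and is a large step, so the group on that ring nitrogen carries much of the change at this position. The same large size appears when 4-methylpiperazin-1-yl replaces methyl((pyridin-3-yl)methyl)amino on a thiocarbonyl carbon, which gives a number 36.2 percentage points higher from compound 1 to compound 4 (beyond the scatter) and leaves the open-chain amine of compound 1 well behind.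

The compounds shown leave open whether the number holds or moves with a hydrogen, an ethyl group or an acetyl group on that ring nitrogen, and how a morpholine ring would compare with the piperazine. No measurement at hand accounts for any of these steps.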